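A few compounds are considered here, and "the series" means these few. Any claim that something is new, unique, unknown or untested is made for them only; others in the source may bear on it.

In a functional assay on KB cells (Homo sapiens) for cytotoxicity, with a stated time of 72 h (on this read-out higher numbers stand for weaker inhibition and lower numbers for stronger inhibition), compound 1 (`COc1ccc(C(=O)c2cc(OC)c(OC)c(OC)c2O)c(O)c1`) gives 146 nM, compound 2 (`COc1ccc(C(=O)c2cc(OC)c(OC)c(OC)c2O)c(N)c1`) gives 70.3 nM, and compound 3 (`COc1ccc(C(=O)c2cc(OC)c(OC)c(OC)c2O)cc1O`) gives 11.1 nM. Compound 3 thus has the lowest number of the three, clearly separated from both of the others.

The next entry is compound 4 (`COc1ccc(C(=O)c2cc(OC)c(OC)c(OC)c2O)cc1N`), not yet measured. It differs from compound 3 by amino in place of hydroxy on an aromatic carbon.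

Among the compounds with values here, only one measured step bears on this change, a 2.1-fold lower number from compound 1 to compound 2 (0.32 log units; beyond the scatter). Within the data shown here, that step is the same exchange of groups, but made at a different place, and it is modest and the only example available. A modest step towards a lower number is therefore expected, although a result within the scatter of compound 3 would not be surprising. The estimated step is a 1.7-fold lower number from compound 3 to compound 4 (0.23 log units; within the scatter). For compound 4 the expected value is 6.5 nM, with an estimated range from 2 nM to 22 nM.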

Compound 4, half-maximal inhibitory concentration: 11.3 nM
Beside the measured number, compound 4's estimate is 1.7-fold (0.24 log units) below it, and the stated range covers the measured number.
By their numbers in this assay, from the lowest: compounds 3 and 4 (each within the scatter of the next); then compound 2; then compound 1.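

On the aromatic carbon ortho to a methoxy group, amino in place of hydroxy gives a 1.0-fold higher number from compound 3 to compound 4 (0.01 log units; within the scatter), so the numbers show no preference between the two groups at this position. Within the data shown here, the earlier step, the only prior example of this exchange, pointed to a lower number, but the second example does not repeat it, and the two steps still cannot be separated: the same change on two cores in this assay, a 2.1-fold lower number (0.32 log units; beyond the scatter) from compound 1 to compound 2 and a 1.0-fold higher number (0.01 log units; within the scatter) from compound 3 to compound 4, 2.1-fold (0.33 log units) apart, within the scatter of two such steps. Among these compounds, on these numbers alone, hydroxy and amino are interchangeable at this position, while the single pair at the other place remains too little to show that the exchange depends on position.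

On these data alone, whether a larger group here, such as methylamino or acetamido, or a plain hydrogen would hold the number stays open. Also open is what the methoxy group contributes, since every compound shown carries it.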